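Cytotoxicity of a Piperidine Amide Series: Estimating a New Analogue

The source may report more compounds than this note shows. Statements on the series, on what has been measured and on what is new or still open speak of the compounds shown alone.

Measured compounds:
compound 1 `Cc1ccccc1-c1nc(CN2CCC(C(=O)NCCCN3CCC(C(C)C)CC3)CC2)c(C)o1` — 4280 nM
compound 2 `Cc1oc(-c2c(F)cccc2F)nc1CN1CCC(C(=O)NCCCN2C[C@H](C)C[C@H](C)C2)CC1` — 32700 nM
compound 3 `Cc1oc(-c2c(Br)cccc2Br)nc1CN1CCC(C(=O)NCCCN2C[C@H](C)C[C@H](C)C2)CC1` — 6500 nM

In an ADME assay on Huh7.5.1 cells (Homo sapiens) for cytotoxicity, read by ATP content, with a stated time of 48 h (on this read-out lower numbers stand for higher toxicity in this test and higher numbers for lower toxicity in this test), compound 1 gives the lowest number of the three. Within the data shown here, compound 3 sits within the scatter of compound 1, while compound 2 lies beyond it, as the only measured step shows: a 5.0-fold lower number from compound 2 to compound 3 (0.70 log units; beyond the scatter). That step concerns the aromatic ring at one end of the shared core and says nothing about the other end.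

Compound 4 `Cc1ccccc1-c1nc(CN2CCC(C(=O)NCCCCN3C[C@H](C)C[C@H](C)C3)CC2)c(C)o1` differs from compound 1 at that other end: (3,5-dimethylpiperidin-1-yl)methyl in place of 4-isopropylpiperidin-1-yl on a saturated chain carbon, three bonds along the chain from an amide-type nitrogen. Among the measured compounds shown here, no measured pair isolates this change. Compounds 2 and 3 carry the same dimethylpiperidine as compound 4, but they also differ from compound 1 in the aromatic ring and in chain length, so their values cannot be read as a guide to this step alone. With nothing in the data pointing either way, no step beyond the scatter is expected, and compound 4 is estimated to fall near compound 1 in this assay, at 5000 nM with a range from 1800 nM to 15000 nM, an expected step of a 1.2-fold higher number from compound 1 to compound 4 (0.07 log units; within the scatter).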

Compound 4, half-maximal cytotoxic concentration: 23100 nM
Compound 4: the middle estimate sits 4.6-fold (0.66 log units) below what was measured; the whole stated range lies below it.
By their numbers in this assay, from the lowest: compounds 1 and 3 (each within the scatter of the next); then compounds 4 and 2 (each within the scatter of the next).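

In this assay this change gives a 5.4-fold higher number from compound 1 to compound 4 (0.73 log units; beyond the scatter) even though the group that leaves and the group that enters hold the same heavy atoms. Among these compounds, the only earlier step concerned the aromatic ring, so this is the first sign that the number also responds to how atoms are arranged at the other end of the molecule. Nothing measured here explains the step.

The change also combines two alterations, a longer chain, seen as 2-(4-isopropylpiperidin-1-yl)ethyl becoming 3-(3,5-dimethylpiperidin-1-yl)propyl, and different groups on the piperidine ring, and the compounds shown do not separate them. On these data alone, it also stays open how this position would respond to a ring holding a second hetero atom, such as morpholine, or to a carboxylic acid on the chain.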